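The compounds below may be only part of what the source reports. "The series", "measured", "known", "first", "only" and "open" are said of these compounds alone.

Compound 2, `Cc1ccc(S(=O)(=O)/N=C(/CCNC2=CC(=O)c3ccccc3C2=O)Nc2ccc(Cl)cc2Cl)cc1`, is a close analogue of compound 1, `Cc1ccc(S(=O)(=O)/N=C(/CCNC2=CC(=O)c3ccccc3C2=O)Nc2cccc(C)c2)cc1`. In a functional assay on DU-145 cells (Homo sapiens) for cytotoxicity, read by MTT assay, with a stated time of 48 h (on this read-out higher numbers stand for weaker inhibition and lower numbers for stronger inhibition), compound 1 gives 10200 nM, and compound 2 gives 18600 nM. Among the measured compounds shown here, the single change between them, 2,4-dichlorophenyl in place of 3-methylphenyl on an amine nitrogen, brought a 1.8-fold higher number from compound 1 to compound 2 (0.26 log units; within the scatter), so compound 2 carries the higher of the two numbers known so far but sits within the scatter of compound 1.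

Compound 3, `Cc1ccc(S(=O)(=O)/N=C(/CCNC2=CC(=O)c3ccccc3C2=O)NC2CCCCC2)cc1`, differs from compound 2 at that same amine nitrogen: cyclohexyl in place of 2,4-dichlorophenyl on an amine nitrogen. For the measured compounds named here, no measured step here exchanges an aromatic ring for a non-aromatic one; the only step available, a 1.8-fold higher number from compound 1 to compound 2 (0.26 log units; within the scatter), swapped one aromatic ring for another and stayed within the scatter. That step gives little reason to expect a large move in this assay, so for compound 3 the expected step is a 1.2-fold lower number from compound 2 to compound 3 (0.09 log units; within the scatter), no bigger than the scatter in either direction. Compound 3 is therefore estimated at 15000 nM, with a range from 5000 nM to 45000 nM.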

Compound 3, half-maximal inhibitory concentration: 16600 nM
Estimate against measurement, compound 3: 1.1-fold (0.04 log units) below, within the range that was stated.
By their numbers in this assay, from the lowest: compounds 1, 3 and 2 (each within the scatter of the next).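

Among the compounds shown here, at this amine nitrogen, the earlier pair showed only one aromatic ring exchanged for another; compound 3 shows that a non-aromatic ring, cyclohexyl, can stand in the same place, with a 1.1-fold lower number from compound 2 to compound 3 (0.05 log units; within the scatter) and a 1.6-fold higher number from compound 1 to compound 3 (0.21 log units; within the scatter) in this assay. Neither the loss of the aromatic ring nor the loss of both chlorine atoms therefore moves the number beyond the usual scatter, and 3-methylphenyl, 2,4-dichlorophenyl and cyclohexyl cannot be told apart here. Nothing available explains why these three compounds read alike.

Going by these compounds, all three groups at this nitrogen are six-membered carbon rings, so it remains open whether something of a different kind, such as a plain methyl, a longer alkyl chain or a chain ending in a carboxylic acid or an amine, would move the number beyond the scatter. On these data alone, it also remains open whether changes elsewhere on the shared core, or the same ring exchanges tested on other cell types, would separate compounds that look alike here.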